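The source may hold more compounds than are shown below. What is called first, only, known or untested is meant among the compounds shown, and "the series" means these compounds.

In an ADME assay on Vero cells (Chlorocebus sabaeus) for antiproliferative activity, read by MTT assay, with a stated time of 72 h (a lower number here means a stronger inhibitor, a higher number a weaker inhibitor), compound 3 (`CCN(c1ccc(Cl)cc1)S(=O)(=O)C1CC2OC1C(c1ccc(NC(=O)CCCCCCC(=O)O)cc1)=C2c1ccc(O)cc1`) gives > 100000 nM, a limit and not a number, so its place in the series cannot be fixed more closely. Compound 1 (`CCN(c1ccc(OC)cc1)S(=O)(=O)C1CC2OC1C(c1ccc(NC(=O)CCCCCCC(=O)O)cc1)=C2c1ccc(O)cc1`) gives > 100000 nM, also a limit. Compound 2 (`CCN(c1ccccc1Cl)S(=O)(=O)C1CC2OC1C(c1ccc(NC(=O)CCCCCCC(=O)O)cc1)=C2c1ccc(O)cc1`) gives > 100000 nM, again a limit. Among the compounds with values here, the series so far shows (the limit of > 100000 nM in this assay, at which 3 of the 3 values shown sit).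

Compound 4 (`CCN(c1ccccc1Br)S(=O)(=O)C1CC2OC1C(c1ccc(NC(=O)CCCCCCC(=O)O)cc1)=C2c1ccc(O)cc1`) carries 2-bromophenyl in place of 4-chlorophenyl on a sulfonamide nitrogen. The nearest measured change is a step that the two limits leave unreadable from compound 2 to compound 3, which exchanges 2-chlorophenyl for 4-chlorophenyl. The other two are a step that the two limits leave unreadable from compound 1 to compound 2 and a step that the two limits leave unreadable from compound 1 to compound 3. None of the three has a readable size, so they give no direction.

Within the data shown here, the expectation rests on all three compounds sitting at the same limit, and no compound gives a number. The estimated change, a number no higher from compound 3 to compound 4 (the limit leaves the size open), is expected to stay within the scatter. Compound 4 is estimated at 100000 nM, with an expected range of 50000 nM to 200000 nM, and will most likely be reported only as a limit.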

Compound 4, half-maximal inhibitory concentration: > 100000 nM
Compound 4: a limit, no number; the forecaster's own chance of this, stated with the estimate: 90%; the middle value lies on the limit itself.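

The steps from compound 1, compound 2 and compound 3 to compound 4 cannot be read in this assay, as each joins two limits: the limit of > 100000 nM in this assay, at which 4 of the 4 values shown sit. The compounds shown leave open whether any of these changes on the sulfonamide nitrogen alters the read-out, and in which direction.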